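The source may report more compounds than this note shows. Statements on the series, on what has been measured and on what is new or still open speak of the compounds shown alone.

Measured compounds:
Compound 1, `O=C(Nc1ccc(-n2ncc3c(C(F)(F)F)cccc32)cc1)Nc1ccc(Cl)c(C(F)(F)F)c1`: 2000 nM
Compound 2, `O=C(Nc1ccc(-n2ncc3c(C(F)(F)F)cccc32)cc1)Nc1ccc(C(F)(F)F)cc1`: 2000 nM

In a functional assay on MDA-MB-231 cells (Homo sapiens) for cytotoxicity, read by MTT assay, with a stated time of 72 h (on this read-out lower numbers stand for stronger inhibition and higher numbers for weaker inhibition), compound 1 gives 2000 nM and compound 2 gives 2000 nM. The only measured step, no change at the digits printed from compound 1 to compound 2 (within the scatter), exchanges one aryl group on an amide-type nitrogen for another, and compound 2 therefore stands level with compound 1 on the numbers shown. Compound 3, `O=C(Nc1ccc(-n2ncc3c(Cl)cccc32)cc1)Nc1ccc(C(F)(F)F)cc1`, differs from compound 2 by chloro in place of trifluoromethyl on an aromatic carbon. For the measured compounds named here, no measured step touches this part of the shared core: the one step recorded concerns the aryl group on the urea nitrogen, not the fused two-ring system, so it gives no direct guide. Going by the values given here, with only two values, both level, the plainest expectation for compound 3 is a result in this assay near that of compound 2, that is no change at the digits printed from compound 2 to compound 3 (within the scatter) as an estimated step. Compound 3 is thus expected to give about 2000 nM, with a range from 800 nM to 5000 nM.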

Compound 3, half-maximal inhibitory concentration: 2700 nM
Estimate against measurement, compound 3: 1.4-fold (0.13 log units) below; the measured number falls inside the stated range.
By their numbers in this assay, from the lowest: compounds 1, 2 and 3 (each within the scatter of the next).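

In this assay, for the compounds shown here, the exchange of trifluoromethyl for chloro on an aromatic carbon of the fused system gives a 1.4-fold higher number from compound 2 to compound 3 (0.13 log units; within the scatter) and is the first measured step at this part of the shared core. A group of 4 heavy atoms thus gives way to one of 1 heavy atom with the number staying within the scatter, which compound 1 and compound 2, differing only in the aryl group on the amide-type nitrogen, could not show. Nothing measured here accounts for this result.

Going by these compounds, it remains open how this position would respond to a group of a different kind, such as an amine, a methoxy group or a carboxylic acid. On these data alone, it is also open whether chloro here would give a similar number with the 4-chloro-3-(trifluoromethyl)phenyl group of compound 1 on the amide-type nitrogen.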